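This account rests on a few compounds, and the source may have more. Where it says the series, first, only, none or still open, it means among the compounds named here.

The compounds here share one core and were tested in an ADME assay on MDCK cells (Canis lupus familiaris) for cytotoxicity, with a stated time of 48 h; on this read-out higher numbers stand for lower toxicity in this test and lower numbers for higher toxicity in this test. In this test compound 3 (`CCC(CC)O[C@@H]1C=C(S(C)(=O)=O)C[C@H](NC(=N)N)[C@H]1NC(C)=O`) gives > 100000 nM, which is a limit of the assay and not a number. Compound 1 (`CCC(CC)O[C@@H]1C=C(S(=O)(=O)CCc2ccncc2)C[C@H](NC(=N)N)[C@H]1NC(C)=O`) gives > 100000 nM, which is also a limit. Compound 2 (`CCC(CC)O[C@@H]1C=C(S(C)(=O)=O)C[C@H](N)[C@H]1NC(C)=O`) offers no reading, and its entry is "not determined" (no result reported). So compound 3 has no exact figure to compare against, and no compound shown has one either.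

Compound 4 (`CCC(CC)O[C@@H]1C=C(S(=O)(=O)O)C[C@H](NC(=N)N)[C@H]1NC(C)=O`) has not yet been measured. It differs from compound 3 at a single place: hydroxy in place of methyl on a sulfonyl sulfur. This puts hydroxy in place of methyl on a sulfonyl sulfur, turning methylsulfonyl into sulfo.

Within the data shown here, only one measured step involves a change on this sulfonyl group: a step that the two limits leave unreadable from compound 1 to compound 3. Going by these compounds, both of its ends are limits, so its size stays unknown. Even so, the result for compound 1 and compound 3 is the same: the limit of > 100000 nM in this assay, at which 2 of the 3 values shown sit. Because of the limit of > 100000 nM in this assay, at which 2 of the 3 values shown sit, no step beyond the usual scatter is expected for this change in this assay, in either direction. The estimated step is a number no higher from compound 3 to compound 4 (the limit leaves the size open). The estimate for compound 4 is 100000 nM, with an expected range from 50000 nM to 200000 nM, and another limit is the likeliest report.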

Compound 4, half-maximal cytotoxic concentration: > 100000 nM
Compound 4: no number, only a limit; the forecaster's own chance of this, stated with the estimate: 90%; the middle value lies on the limit itself.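

No step can be read from compound 1 or compound 3 to compound 4, because all three results are limits of the assay and not numbers: the limit of > 100000 nM in this assay, at which 3 of the 4 values shown sit. Going by these compounds, what stays open is whether hydroxy, methyl and 2-(pyridin-4-yl)ethyl on the sulfonyl sulfur differ at all in this assay, and if so, by how much.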